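The source may report more compounds than this note shows. Statements on the series, on what has been measured and on what is new or still open speak of the compounds shown alone.

Compound 1 `O=C1c2ccc(OCc3cccc(-c4ccc(Cl)cc4F)c3)cc2CN1C1CCCC1`: "not determined" (no result reported) in an ADME assay on microsomes from liver (Rattus norvegicus) for metabolic stability, read by LC-MS, with a stated time of 1 h, at 37 degrees C, tested at 4 uM; a lower number here means that less of the compound is left, a higher number that more of the compound is left
Compound 2 `O=C1c2ccc(OCc3cccc(-c4ccccc4)c3)cc2CN1C1CCCC1`: 38% in this assay

Among the measured compounds shown here, compound 2 carries the only number in this assay, at 38%; compound 1 has no reported result, so compound 2 has no measured neighbour to be compared with. Compound 3 `COc1ccc(C(=O)O)cc1-c1cccc(COc2ccc3c(c2)CN(C2CCCC2)C3=O)c1` keeps the shared core and has 5-carboxy-2-methoxyphenyl in place of phenyl on an aromatic carbon. For the measured compounds named here, no measured step speaks to this change, so the expectation is only a rough one: an upward move of moderate size, with more of the compound left. The estimated change is a number 24 percentage points higher from compound 2 to compound 3 (beyond the scatter). Compound 3 is expected at 62%, with an estimated range of 38% to 88%.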

Compound 3, percent of the compound remaining: 30%
Compound 3: the middle estimate sits 32 percentage points above what was measured, outside the stated range (below it).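

Placing 5-carboxy-2-methoxyphenyl in place of phenyl on this aromatic carbon gives the first measured step at this position in this assay, a number 8 percentage points lower from compound 2 to compound 3 (within the scatter). A substantially larger ring substituent, carrying both a carboxy and a methoxy group, therefore leaves the percentage of compound remaining within the usual scatter. No available measurement explains this outcome.

The compounds shown do not separate the contribution of the carboxy group from that of the methoxy group. On these data alone, how an amine or a nitrile on this ring would read in this assay also remains open.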